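A few compounds are considered here, and "the series" means these few. Any claim that something is new, unique, unknown or untested is made for them only; others in the source may bear on it.

Working notes on the thiourea/urea pair series.

Compound 1, `CC1(C)CCNc2ccc(NC(=S)Nc3ccc(C(F)(F)F)cc3)cc21`, measured in an assay on isolated protein for binding affinity to stress-70 protein, mitochondrial (Homo sapiens) (a higher number here means weaker binding, a lower number tighter binding), gives 3300 nM. Compound 2, `CC1(C)CCNc2ccc(NC(=S)Nc3ccc(OC(F)(F)F)cc3)cc21`, is the same molecule carrying trifluoromethoxy in place of trifluoromethyl on an aromatic carbon and in this assay gives 5400 nM. That one exchange made a 1.6-fold higher number from compound 1 to compound 2 (0.21 log units; within the scatter), a step the data mark as within the scatter, so the two values cannot be ordered against each other.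

Compound 3, `CN1c2ccc(NC(=O)Nc3ccc(C(F)(F)F)cc3)cc2C(C)(C)C(=O)C1(C)C`, is built on a different core; how that core differs from the core of compound 1 is not broken down here. In this assay compound 3 gives 1500 nM, the lowest number of the three, with its nearest neighbour compound 1 and its furthest neighbour compound 2, both gaps beyond the scatter.

Compound 4, `CN1c2ccc(NC(=O)Nc3ccc(OC(F)(F)F)cc3)cc2C(C)(C)C(=O)C1(C)C`, has not yet been measured. For the measured compounds named here, it carries trifluoromethoxy in place of trifluoromethyl on an aromatic carbon relative to compound 3, and its place line reads word for word as the one for the step from compound 1 to compound 2, so it is the same change made on the second core. Going by the values given here, with only one measured instance of this change to lean on, the expectation for compound 4 is a step of a 1.6-fold higher number from compound 3 to compound 4 (0.20 log units; within the scatter), resting on the earlier 1.6-fold higher number from compound 1 to compound 2 (0.21 log units; within the scatter). Compound 4 is accordingly estimated at 2400 nM in this assay, with a likely range from 1200 nM to 5000 nM; the measured value will show whether the second core carries the change the same way.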

Compound 4, dissociation constant: 1800 nM
The estimate for compound 4 lay 1.3-fold (0.12 log units) above the measured number, and the stated range covers the measured number.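

In this assay, the exchange of trifluoromethyl for trifluoromethoxy on the second core gives a 1.2-fold higher number from compound 3 to compound 4 (0.08 log units; within the scatter), so the two values cannot be ordered against each other. Set beside the earlier step, the exchange reads the same on both cores: the same change on two cores in this assay, a 1.6-fold higher number (0.21 log units; within the scatter) from compound 1 to compound 2 and a 1.2-fold higher number (0.08 log units; within the scatter) from compound 3 to compound 4, 1.4-fold (0.13 log units) apart, within the scatter of two such steps

For these two pairs, this shows that the exchange stays within the scatter on each core and that nothing separates its size on one core from its size on the other; it does not show that the two groups are interchangeable in general, that a small real difference is absent, or that the result extends to any other core or any other assay.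

The compounds shown leave open whether other groups in this place, para to a large group, such as a nitrile, an amine or a carboxylic acid, would carry from one core to the other in the same way. They also leave open how a thiourea on the core of compound 3, or a urea on the core of compound 1, would behave, so the thiourea-to-urea exchange cannot be separated from the other differences between the two cores.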